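Side-chain variation on the shared core: working notes

The source may report more compounds than this note shows. Statements on the series, on what has been measured and on what is new or still open speak of the compounds shown alone.

Measured in an assay on cells for agonist activity at vitamin D3 receptor (Homo sapiens), read by microscopy; on this read-out higher numbers stand for an effect only at larger amounts of compound and lower numbers for an effect already at smaller amounts:
compound 1 `CCN(CC)CCNC(=O)c1cc(C(CC)(CC)c2ccc(C#CC(O)(CC)CC)c(C)c2)cn1CC`: 6.98 nM
compound 2 `CCn1cc(C(CC)(CC)c2ccc(C#CC(O)(CC)CC)c(C)c2)cc1C(=O)OCCO`: 12.6 nM
compound 3 `CCn1cc(C(CC)(CC)c2ccc(C#CC(O)(CC)CC)c(C)c2)cc1C(=O)NCC(=O)O`: 54.3 nM

Compound 3 stands highest of the three numbers in this assay; the nearest is compound 2, a 4.3-fold higher number from compound 2 to compound 3 (0.63 log units; beyond the scatter), and the furthest is compound 1, a 7.8-fold higher number from compound 1 to compound 3 (0.89 log units; beyond the scatter). Compound 1 and compound 2 sit close together, a 1.8-fold higher number from compound 1 to compound 2 (0.26 log units; within the scatter).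

Compound 4 `CCn1cc(C(CC)(CC)c2ccc(C#CC(O)(CC)CC)c(C)c2)cc1C(=O)N[C@@H](C)CO` is unmeasured. Its change from compound 3 is 1-(hydroxymethyl)ethyl in place of carboxymethyl on an amide-type nitrogen. Within the data shown here, the step that bears most directly on it is the one from compound 2 to compound 3, where a hydroxyl-terminated side chain went to a carboxy-terminated one and the number rose, a 4.3-fold higher number from compound 2 to compound 3 (0.63 log units; beyond the scatter); compound 4 again carries a hydroxyl end and no carboxy, so that rise is expected to be undone in large part. The step from compound 1 to compound 3 points the same way, a 7.8-fold higher number from compound 1 to compound 3 (0.89 log units; beyond the scatter). A fall in the number in this assay beyond the scatter is therefore expected for compound 4, a 3.6-fold lower number from compound 3 to compound 4 (0.56 log units; beyond the scatter), landing near compound 2. The estimate for compound 4 in this assay is 15 nM, with a range from 6 nM to 40 nM.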

Compound 4, half-maximal effective concentration: 7.33 nM
For compound 4 the middle estimate is 2.0-fold (0.31 log units) above the measured one; low and high end bracket the measured number.
By their numbers in this assay, from the lowest: compounds 1, 4 and 2 (each within the scatter of the next); then compound 3.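

In this assay, the amide-type nitrogen takes 1-(hydroxymethyl)ethyl in place of carboxymethyl with a 7.4-fold lower number from compound 3 to compound 4 (0.87 log units; beyond the scatter), so a swap that keeps the heavy-atom count of the group still moves the number beyond the scatter. Among these compounds, compound 4 falls in with the other two, with a 1.7-fold lower number from compound 2 to compound 4 (0.24 log units; within the scatter) and a 1.1-fold higher number from compound 1 to compound 4 (0.02 log units; within the scatter); a hydroxyl-ended group on the amide-type nitrogen therefore reads the same as the 2-(diethylamino)ethyl group of compound 1 and the 2-hydroxyethoxy group of compound 2, which leaves compound 3, the only compound with a carboxy end, apart from all three. Nothing available explains this difference.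

The compounds shown do not separate the loss of the carboxylic acid from the gain of the branching methyl and the defined stereocentre of 1-(hydroxymethyl)ethyl; a straight 2-hydroxyethyl group on the same nitrogen, the opposite stereoisomer, and a methyl ester of the acid would each bear on that. Also open, as far as these compounds go, is how a longer chain ending in hydroxyl or in a carboxylic acid would read at this position.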